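A few compounds are considered here, and "the series" means these few. Any claim that something is new, unique, unknown or untested is made for them only; others in the source may bear on it.

Measured compounds:
Compound 1, `CC1=C(C(=O)OCc2ccccc2)C(c2cccs2)NC(=O)N1`, in an assay on membranes from HeLa cells for displacement of a labelled ligand from adenosine receptor A3 (Homo sapiens), read by scintillation counting, with a stated time of 180 min, tested at 1 uM (on this read-out lower numbers stand for less inhibition and higher numbers for more inhibition at the one concentration tested (going by the name of the read-out)), compound 1 gives 8%.
Compound 2, `CC1=C(C(=O)CC(C)C)C(c2cccs2)NC(=O)N1`, compound 2 gives 18%.
Compound 3, `CCNC(=O)C1=C(C)NC(=O)NC1c1cccs1`, compound 3 gives 4%.

Compound 3 stands lowest of the three numbers, though its gap to compound 1 lies within the scatter; only compound 2 stands beyond the scatter above it. Among the measured compounds shown here, the one step among the measured compounds that touches the same carbonyl carbon is a number 14 percentage points lower from compound 2 to compound 3 (beyond the scatter), where an ethylamino group replaced an isobutyl group.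

Compound 4, `CC1=C(C(=O)OC2CCCCC2)C(c2cccs2)NC(=O)N1`, is not yet measured. It differs from compound 3 in one place: cyclohexyloxy in place of ethylamino on a carbonyl carbon. This change reverses the direction of the measured step, taking the ethylamino group back out and putting an ester group in its place, which makes compound 4 resemble compound 1 more than compound 2. Compound 1 and compound 3 sit within the scatter of each other, so the account leans on that pair rather than on the larger step from compound 2. Compound 4 is therefore expected to show a small rise, a number 6 percentage points higher from compound 3 to compound 4 (within the scatter), that may not exceed the scatter. The estimate for compound 4 in this assay is 10%, with a range from 0% to 24%.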

Compound 4, a percentage reported as inhibition, at one concentration (the size of the read-out at that concentration, not a potency): 1%
Estimate against measurement, compound 4: 9 percentage points above; the measured number falls inside the stated range.
By their numbers in this assay, from the lowest: compounds 4, 3, 1 and 2 (each within the scatter of the next, the first and the last beyond it).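

In this assay the carbonyl carbon now carries a cyclohexyloxy group, with its six-membered non-aromatic ring of carbon only, and this exchange for ethylamino gives no change that can be told from the scatter (a number 3 percentage points lower from compound 3 to compound 4 (within the scatter)). Among the two esters, cyclohexyl in place of benzyl on an oxygen next to a carbonyl group likewise stays within the scatter (a number 7 percentage points lower from compound 1 to compound 4 (within the scatter)), so neither change separates these compounds on this read-out. Cyclohexyloxy in place of isobutyl gives a modest difference beyond the scatter (a number 17 percentage points lower from compound 2 to compound 4 (beyond the scatter)), matching the direction of the ethylamino exchange, although compound 1 does not fit a simple split between isobutyl and the other groups, since the printed order places it within the scatter of compound 2.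

Going by these compounds, whether a carboxylic acid, an amine without the ethyl group or a longer chain on this carbonyl carbon would lift the number clear of all four compounds remains open. Nothing available here bears on the reason for these numbers.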